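Epimer at the sec-butyl chain carbon

A few compounds are considered here, and "the series" means these few. Any claim that something is new, unique, unknown or untested is made for them only; others in the source may bear on it.

Within the data shown here, in an in vivo ADME assay on the whole organism for pharmacokinetics, with Rattus norvegicus as the target, at a dose of 5 mg/kg (a higher number here means faster removal of the compound, a lower number slower removal), compound 1 `CCC(CC)[C@@H]1C(=O)N[C@H](C2Cc3ccccc3C2)C(=O)N1[C@@H](C(=O)N1CCOCC1)c1ccc(C)nc1` gives 23 mL/min/kg and compound 2 `CC[C@@H](C)[C@@H]1C(=O)N[C@H](C2Cc3ccccc3C2)C(=O)N1[C@@H](C(=O)N1CCOCC1)c1ccc(C)nc1` gives 39 mL/min/kg within the scatter of each other, so compound 2 stands level with the only other measured compound. Among the measured compounds shown here, the one measured step, a 1.7-fold higher number from compound 1 to compound 2 (0.23 log units; within the scatter) with sec-butyl in place of pentan-3-yl, lies within the scatter. For the measured compounds named here, the change to compound 3 `CC[C@H](C)[C@@H]1C(=O)N[C@H](C2Cc3ccccc3C2)C(=O)N1[C@@H](C(=O)N1CCOCC1)c1ccc(C)nc1` is the two compounds have the same atoms and bonds and differ only in configuration as drawn: 1 of 4 stereo elements differ; a stereocentre at a saturated chain carbon is drawn R in compound 2 and S in compound 3 and no measured step tests a change of that kind. No step beyond the scatter is expected in this assay and a 1.1-fold lower number from compound 2 to compound 3 (0.06 log units; within the scatter) is the estimated size. Compound 3 is estimated at 34 mL/min/kg with an expected range from 17 mL/min/kg to 68 mL/min/kg in this series.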

Compound 3, clearance: 27 mL/min/kg
Compound 3: the middle estimate sits 1.3-fold (0.10 log units) above what was measured; the measured number falls inside the stated range.
By their numbers in this assay, from the lowest: compounds 1, 3 and 2 (each within the scatter of the next).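

In this assay, the stereocentre at the saturated chain carbon of the sec-butyl group is now put to the test, and its inversion gives a 1.4-fold lower number from compound 2 to compound 3 (0.16 log units; within the scatter) with no step beyond the scatter. The S form likewise stays level with the pentan-3-yl compound, with a 1.2-fold higher number from compound 1 to compound 3 (0.07 log units; within the scatter) for sec-butyl in place of pentan-3-yl. This comparison isolates the stereocentre: the fact that compounds 2 and 3 differ only in the configuration as drawn

Still open, from the compounds shown here alone, is whether a cyclopropyl, a phenyl or a methoxyethyl group on that saturated ring carbon would shift clearance beyond the scatter.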